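The compounds below may be only part of what the source reports. "The series", "measured", "known", "first", "only" and "open" are said of these compounds alone.

Compound 1 `CC1(C)[C@H]2CC[C@]1(C)N(Cc1cn(-c3cccc(F)c3)nn1)C(=O)C2` gives 180 nM
Compound 2 `CC1(C)[C@H]2CC[C@]1(C)N(Cc1cn(-c3ccc(Cl)cc3)nn1)C(=O)C2` gives 70 nM

For the measured compounds named here, in a functional assay on A549 cells (Homo sapiens) for inhibition, read by MTT assay, with a stated time of 24 h (a lower number here means a stronger inhibitor, a higher number a weaker inhibitor), compound 2 at 70 nM holds the lower of the two numbers measured so far. Compound 3 `COc1cccc(-n2cc(CN3C(=O)C[C@@H]4CC[C@@]3(C)C4(C)C)nn2)c1` differs from it on an aromatic nitrogen, with 3-methoxyphenyl in place of 4-chlorophenyl (3-methoxyphenyl in place of 4-chlorophenyl on an aromatic nitrogen). Going by the values given here, the only measured step bearing on this is modest (a 2.6-fold lower number from compound 1 to compound 2 (0.41 log units; beyond the scatter)), and it brought in the 4-chlorophenyl that now leaves. So in this assay a modest step to a higher number is expected. The estimated step (a 2.1-fold higher number from compound 2 to compound 3 (0.33 log units; beyond the scatter)) is of similar size. Compound 3 is expected at 150 nM (estimated range 60 nM to 400 nM).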

Compound 3, half-maximal inhibitory concentration: 240 nM
The estimate for compound 3 lay 1.6-fold (0.20 log units) below the measured number; the range from low to high includes it.
By their numbers in this assay, from the lowest: compound 2; then compounds 1 and 3 (each within the scatter of the next).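

In this assay the step of a 3.4-fold higher number from compound 2 to compound 3 (0.54 log units; beyond the scatter) shows that 3-methoxyphenyl on the aromatic nitrogen does not hold the low number reached with 4-chlorophenyl. Methoxy in place of fluoro on an aromatic carbon gives a 1.3-fold higher number from compound 1 to compound 3 (0.12 log units; within the scatter), so of these three compounds only compound 2 stands apart. No evidence shown accounts for this difference.

Going by these compounds, it remains open whether the lower number of compound 2 follows the chlorine itself or its place on the phenyl ring, as both change together in these steps. On these data alone, how a phenyl ring bearing an amine or a carboxylic acid would read is also open.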